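Thiocarbamate series on breast cancer cells: aryl swap on the oxadiazole

The source may hold more compounds than are shown below. What is called first, only, known or untested is meant among the compounds shown, and "the series" means these compounds.

Measured so far:
- compound 1, `CC(=O)CCSC(=S)NCc1cccnc1`: 1120 nM
- compound 2, `S=C(NCc1cccnc1)SCCn1nc2ccccc2n1`: 980 nM
- compound 3, `S=C(NCc1cccnc1)SCCc1nnc(-c2ccccc2)o1`: 580 nM

All three compounds share the thiocarbamate core and have been run in a functional assay on SK-BR-3 cells (Homo sapiens) for cytotoxicity, read by resazurin assay, with a stated time of 72 h; on this read-out lower numbers stand for stronger inhibition and higher numbers for weaker inhibition. Compound 3 gives 580 nM, the lowest number of the three, yet compound 2 with 980 nM and compound 1 with 1120 nM both sit within the scatter of it, so no ordering among the three is supported by these numbers.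

The next compound, compound 4, `S=C(NCc1cccnc1)SCCc1nnc(-c2cnccn2)o1`, differs from compound 3 in one place: pyrazin-2-yl in place of phenyl on an aromatic carbon. For the measured compounds named here, no pair of measured compounds in this set differs in a single place, so there is no measured step to lean on for the size of this change. The expectation is therefore anchored on compound 3 alone: a step from compound 3 to compound 4 of a 1.1-fold higher number from compound 3 to compound 4 (0.05 log units; within the scatter) is expected, with no direction favoured beyond the scatter. For compound 4 the estimate in this assay is 650 nM, with a range from 220 nM to 1900 nM.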

Compound 4, half-maximal inhibitory concentration: 1290 nM
Estimate against measurement, compound 4: 2.0-fold (0.30 log units) below; measured number inside the range.
By their numbers in this assay, from the lowest: compounds 3, 2, 1 and 4 (each within the scatter of the next, the first and the last beyond it).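

In this assay, for the compounds shown here, pyrazin-2-yl in place of phenyl on the aromatic carbon of the five-membered ring gives a 2.2-fold higher number from compound 3 to compound 4 (0.35 log units; beyond the scatter), a modest step but the first single-place comparison, and it lies beyond the scatter. This position therefore shows a measurable response to the identity of the aromatic ring, with the count of 6 heavy atoms unchanged as a ring of carbon only gives way to one with 2 hetero atoms. Nothing on hand accounts for the step.

On these data alone, whether pyridinyl, with a single ring nitrogen, would stay with phenyl or follow pyrazin-2-yl remains open. Also open, as far as these compounds go, is whether a chlorophenyl or methoxyphenyl group at this position would give a number lower than that of phenyl.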